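A few compounds are considered here, and "the series" means these few. Any claim that something is new, unique, unknown or untested is made for them only; others in the source may bear on it.

Working notes on the series. Of the compounds shown here, two so far carry numbers in a functional assay on HeLa cells (Homo sapiens) for cytotoxicity, read by MTT assay, with a stated time of 72 h; a lower number here means a stronger inhibitor, a higher number a weaker inhibitor. Compound 1 `Cc1cccc(CSc2cc(Cl)c(C)cc2S(=O)(=O)/N=C(\N)n2nccc2-c2ccccc2)c1` gives 8000 nM. Compound 2 `Cc1cc(-c2ccccc2)n(/C(N)=N/S(=O)(=O)c2cc(C)c(Cl)cc2SCc2ccc(C(F)(F)F)cc2)n1` gives 19000 nM, the highest of the two numbers; its gap to compound 1 lies beyond the usual scatter. Compound 3 `Cc1ccc(CSc2cc(Cl)c(C)cc2S(=O)(=O)/N=C(\N)n2nc(C)cc2-c2ccccc2)cc1` has yet to be measured in this assay. It differs from compound 2 in a single place: methyl in place of trifluoromethyl on an aromatic carbon. Otherwise compound 3 matches compound 2 throughout. Among the measured compounds shown here, no step between measured compounds covers this change, so the expectation rests on the two values alone. Compound 1, the other compound carrying a methyl rather than a trifluoromethyl in that region, gives the lower number of the pair. For compound 3 the step of a 1.6-fold lower number from compound 2 to compound 3 (0.20 log units; within the scatter) is expected, a modest move toward a lower number that may not clear the scatter. Compound 3 is accordingly estimated at 12000 nM, with a range of 5000 nM to 30000 nM.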

Compound 3, half-maximal inhibitory concentration: 62000 nM
For compound 3 the middle estimate is 5.2-fold (0.71 log units) below the measured one; measured number above the stated range.
By their numbers in this assay, from the lowest: compound 1; then compound 2; then compound 3.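

Within this assay, the change from 4-(trifluoromethyl)benzyl to 4-methylbenzyl on an otherwise shared core gives a 3.3-fold higher number from compound 2 to compound 3 (0.51 log units; beyond the scatter). Among the compounds shown here, this is the first one-place comparison, and it shows that the group on this aromatic carbon can alone move the number beyond the scatter. Of these two groups, trifluoromethyl goes with the lower number and methyl with the higher, a reading that holds for this single pair only.

The compounds shown leave open how an amine, a methoxy group or a carboxylic acid on this aromatic carbon would compare with trifluoromethyl and methyl. They also leave open whether the same change gives a step of similar size and direction on other variants of the core. The data shown offer no measurement that explains this step.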